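Swapping the amide-bearing ring for a phenethyl chain

The source may report more compounds than this note shows. Statements on the series, on what has been measured and on what is new or still open speak of the compounds shown alone.

Of the compounds shown here, three sharing one core have been measured in a functional assay on liver (Sus scrofa) for inhibition of squalene monooxygenase (Homo sapiens), using microsomes; on this read-out lower numbers stand for stronger inhibition and higher numbers for weaker inhibition. Compound 1 `CCN(C/C=C/C#CC(C)(C)C)Cc1cccc(OC[Si](C)(C)c2ccc(Cl)cc2)c1` gives 400 nM, compound 2 `CCN(C/C=C/C#CC(C)(C)C)Cc1cccc(OC[Si](C)(C)c2ccccc2C)c1` gives 30 nM, and compound 3 `CCN(C/C=C/C#CC(C)(C)C)Cc1cccc(OC[Si](C)(C)c2ccc(C(N)=O)cc2)c1` gives 5000 nM, the highest number of the three. Compound 4 `CCN(C/C=C/C#CC(C)(C)C)Cc1cccc(OC[Si](C)(C)CCc2ccccc2)c1` differs from compound 3 in one place: phenethyl in place of 4-carbamoylphenyl on a silicon. Among the compounds with values here, the steps that bear on this are the move a 13-fold higher number from compound 1 to compound 3 (1.10 log units; beyond the scatter) and the move a 170-fold higher number from compound 2 to compound 3 (2.22 log units; beyond the scatter), both introducing the 4-carbamoylphenyl that compound 4 now loses. Reversing that change is therefore expected to bring a large drop, estimated as a 25-fold lower number from compound 3 to compound 4 (1.40 log units; beyond the scatter) in this assay. Compound 4 is expected to give about 200 nM, in a range from 40 nM to 1000 nM.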

Compound 4, half-maximal inhibitory concentration: > 10000 nM
Compound 4 gave a limit, no number; the forecaster's own chance of this, stated with the estimate: 2%; middle value at least 50-fold (1.69 log units) away from the limit.
By their numbers in this assay, from the lowest: compound 2; then compound 1; then compound 3. At a limit, above all of these: compound 4.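

In this assay compound 4 gives a limit, not a number: the limit of > 10000 nM in this assay, at which 1 of the 4 values shown sits. Losing the 4-carbamoylphenyl therefore does not restore inhibition when phenethyl enters, as shown by an at least 330-fold higher number from compound 2 to compound 4 (2.52 log units; beyond the scatter) and an at least 25-fold higher number from compound 1 to compound 4 (1.39 log units; beyond the scatter). Compound 1 and compound 2 carry a substituted phenyl on the silicon, but so does compound 3, which goes against any simple rule, and an at least 2.0-fold higher number from compound 3 to compound 4 (0.30 log units; that floor lies within the scatter) cannot rank compound 3 and compound 4. From the compounds shown here alone, it remains open how a benzyl or an unsubstituted phenyl on the silicon would read, and whether any such group comes near compound 2.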